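Phenyl for Allyl on a Thiourea Sulfonamide Series

The source may hold more compounds than are shown below. What is called first, only, known or untested is meant among the compounds shown, and "the series" means these compounds.

Compound 1 `C=CCNC(=S)NS(=O)(=O)c1ccc(-n2nc(C(=O)O)cc2C)cc1` gives -6% in a functional assay on the whole organism (blood, strain albino) with Mus musculus as the target, with stated times of 6 days and 4 h, at a dose of 0.4 mmol/kg by the oral route; a lower number here means less inhibition, a higher number more inhibition at the dose given (going by the name of the read-out). Compound 2 `Cc1cc(C)n(-c2ccc(S(=O)(=O)NC(=O)NNC(=N)N)cc2)n1` gives 3% in this assay. Compound 3 `Cc1cc(C)n(-c2ccc(S(=O)(=O)NC(=S)NCc3ccccc3)cc2)n1` gives 0% in this assay.

Compound 1 holds the lowest number of the three, yet its gaps to compound 3 and to compound 2 both lie within the scatter, so the three numbers are best read as alike and close to no effect. Compound 4 `Cc1cc(C(=O)O)nn1-c1ccc(S(=O)(=O)NC(=S)Nc2ccccc2)cc1` has not yet been measured. It differs from compound 1 in one place: phenyl in place of allyl on an amide-type nitrogen. Nothing among the three measured compounds points to a shift from this change. In this assay the step of a number 7 percentage points higher from compound 1 to compound 4 (within the scatter) is expected to stay within the scatter, with no direction claimed. Compound 4 is therefore estimated at 1%, with a range from -12% to 14%.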

Compound 4, a percentage reported as inhibition, in the whole organism at one dose (the size of the read-out at that dose, not a potency): 0%
Compound 4: the middle estimate sits 1 percentage points above what was measured, and the stated range covers the measured number.
By their numbers in this assay, from the lowest: compounds 1, 3, 4 and 2 (each within the scatter of the next).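

Phenyl in place of allyl on the amide-type nitrogen gives a number 6 percentage points higher from compound 1 to compound 4 (within the scatter) in this assay. At this position, then, an aromatic ring can replace the allyl chain with no readable shift, and the read-out stays close to no effect. No other information bears on a reason for this result.

From the compounds shown here alone, whether a cyclohexyl group or a longer chain on this nitrogen would move the read-out beyond the scatter remains open. So does whether an amine on the added phenyl would do so.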